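Swapping hydroxyl for methoxy on the cyclohexylmethyl side chain

The compounds below may be only part of what the source reports. "The series", "measured", "known", "first", "only" and "open" are said of these compounds alone.

In an ADME assay on S9 fraction from liver (Homo sapiens) for metabolic stability, with a stated time of 1 h (a lower number here means that less of the compound is left, a higher number that more of the compound is left), compound 3 `N#Cc1cnc(NCc2cnccc2C(F)(F)F)cc1NC[C@H]1CC[C@H](O)CC1` gives 32%. This puts it second of the three measured compounds, with compound 1 `N#Cc1cnc(NCc2cnccc2C(F)(F)F)cc1NC[C@H]1C[C@@H](O)C1` at 84% and compound 2 `CO[C@H]1CC[C@@H](Nc2cc(NCc3cnccc3C(F)(F)F)ncc2C#N)CC1` at 19%.

The next compound, compound 4 `CO[C@H]1CC[C@@H](CNc2cc(NCc3cnccc3C(F)(F)F)ncc2C#N)CC1`, has not yet been measured. It keeps the shared core of compound 3 and changes one group: 4-methoxycyclohexyl in place of 4-hydroxycyclohexyl on a saturated chain carbon bound to a nitrogen on an aromatic ring. The side chain thus goes from (4-hydroxycyclohexyl)methyl to (4-methoxycyclohexyl)methyl.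

Within the data shown here, no measured pair makes exactly this swap. The closest evidence is the modest step of a number 13 percentage points higher from compound 2 to compound 3 (beyond the scatter), which places (4-hydroxycyclohexyl)methyl where 4-methoxycyclohexyl stood. That step mixes the hydroxyl and methoxy difference with a different attachment to the nitrogen, so it is only a partial guide. The large steps of a number 65 percentage points lower from compound 1 to compound 2 (beyond the scatter) and a number 52 percentage points lower from compound 1 to compound 3 (beyond the scatter) both start from the cyclobutyl side chain of compound 1. They show how far the number can move among these compounds, but they do not isolate this swap.

A modest fall is therefore expected, and the estimated result is a number 14 percentage points lower from compound 3 to compound 4 (beyond the scatter). For compound 4 the estimated value is 18%, with an expected range from 6% to 38%.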

Compound 4, percent of the compound remaining: 4%
The estimate for compound 4 lay 14 percentage points above the measured number; the measured number lies below the stated range.
By their numbers in this assay, from the lowest: compound 4; then compound 2; then compound 3; then compound 1.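

Here the swap stands alone: with the link to the nitrogen unchanged, 4-methoxycyclohexyl in place of 4-hydroxycyclohexyl gives a number 28 percentage points lower from compound 3 to compound 4 (beyond the scatter) in this assay and removes the hydrogen-bond donor that the hydroxyl group carried. The methoxy group can now also be held constant while the attachment changes, and going from 4-methoxycyclohexyl to (4-methoxycyclohexyl)methyl on the nitrogen gives a number 15 percentage points lower from compound 2 to compound 4 (beyond the scatter) as a second, separate step downward. Compound 4 now has the lowest number of the four, and the change in side chain from compound 1 spans the widest gap in the set, with a number 80 percentage points lower from compound 1 to compound 4 (beyond the scatter) as the result.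

Nothing measured here explains why the methoxy compound is left in a smaller amount than the hydroxyl compound. On these data alone, it also remains open how the number would respond to a methoxy group on the cyclobutyl side chain of compound 1, or to an amine or a carboxylic acid in place of the hydroxyl group on the cyclohexyl ring of compound 3.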